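A benzyl group on the ring nitrogen of compound 1

This account rests on a few compounds, and the source may have more. Where it says the series, first, only, none or still open, it means among the compounds named here.

Compound 1, `C=C1C(=O)O[C@H]2[C@H]1CC/C(COC(=O)Cn1cc(F)c(=O)[nH]c1=O)=C\CC[C@@]1(C)O[C@@H]21`: > 20000 nM
Compound 2, `C=C1C(=O)O[C@H]2[C@H]1CC/C(COC(=O)Cn1cc(F)c(=O)n(Cc3ccc([N+](=O)[O-])cc3)c1=O)=C\CC[C@@]1(C)O[C@@H]21`: 4070 nM
Compound 3, `C=C1C(=O)O[C@H]2[C@H]1CC/C(COC(=O)Cn1cc(F)c(=O)n(Cc3cccc(F)c3)c1=O)=C\CC[C@@]1(C)O[C@@H]21`: 2530 nM

In a functional assay on Bel-7402 cells (Homo sapiens) for antiproliferative activity, read by MTT assay, with a stated time of 72 h (on this read-out higher numbers stand for weaker inhibition and lower numbers for stronger inhibition), compound 1 reaches only the limit (the limit of > 20000 nM in this assay, at which 1 of the 3 values shown sits), so for compound 1 there is no number, only that limit. Compound 2 gives 4070 nM in this assay, and compound 3 gives 2530 nM. The two measured steps from compound 1 both go the same way: an at least 4.9-fold lower number from compound 1 to compound 2 (0.69 log units; beyond the scatter), and an at least 7.9-fold lower number from compound 1 to compound 3 (0.89 log units; beyond the scatter). Between the two substituted compounds the difference is small: a 1.6-fold lower number from compound 2 to compound 3 (0.21 log units; within the scatter).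

Compound 4, `C=C1C(=O)O[C@H]2[C@H]1CC/C(COC(=O)Cn1cc(F)c(=O)n(Cc3cc(F)ccc3F)c1=O)=C\CC[C@@]1(C)O[C@@H]21`, is not yet measured. It differs from compound 1 in one place: 2,5-difluorobenzyl in place of hydrogen on an aromatic nitrogen. This change belongs to the same family as those in compound 2 and compound 3, a benzyl group entering on the aromatic nitrogen, and both of those steps were at least modest in the direction of a lower number. The step from compound 1 to compound 4 is therefore expected to be at least modest in the same direction, an at least 7.1-fold lower number from compound 1 to compound 4 (0.85 log units; beyond the scatter), with the value most likely near that of compound 3. For compound 4 in this assay the estimate is 2800 nM, within 1000 nM to 8000 nM.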

Compound 4, half-maximal inhibitory concentration: 3060 nM
Compound 4: middle estimate off by 1.1-fold (0.04 log units), on the low side, and the stated range covers the measured number.
By their numbers in this assay, from the lowest: compounds 3, 4 and 2 (each within the scatter of the next). At a limit, above all of these: compound 1.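

The 2,5-difluorobenzyl group on the aromatic nitrogen gives an at least 6.5-fold lower number from compound 1 to compound 4 (0.81 log units; beyond the scatter) in this assay, so all three benzyl groups shown at this position go the same way, and none goes against it. What is new is how little the ring substituents of the benzyl group separate these compounds: adding a second fluoro group leaves a 1.2-fold higher number from compound 3 to compound 4 (0.08 log units; within the scatter), and exchanging the 4-nitrobenzyl group for the 2,5-difluorobenzyl group leaves a 1.3-fold lower number from compound 2 to compound 4 (0.12 log units; within the scatter), so compound 2, compound 3 and compound 4 cannot be told apart despite their different substituents. Compound 1 remains a limit and not a number, so the full size of the step stays unknown: the limit of > 20000 nM in this assay, at which 1 of the 4 values shown sits.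

On these data alone, whether a plain methyl group or an unsubstituted benzyl group on the same nitrogen would give a number in this range stays open. So does whether a longer chain such as phenethyl, or a benzyl group carrying an amine or a carboxylic acid, would shift the number beyond the scatter.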